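Weak Cytotoxicity and a Dichlorophenyl Replacement

A few compounds are considered here, and "the series" means these few. Any claim that something is new, unique, unknown or untested is made for them only; others in the source may bear on it.

Compound 1 `COc1ccc(C2C(C#N)=C(N)N(c3cc(OC)c(OC)c(OC)c3)C3=C2C(=O)CC(C)(C)C3)cc1`: "not active" (no number reported)
Compound 2 `COc1cc(N2C(N)=C(C#N)C(c3c(OC)ccc4ccccc34)C3=C2CC(C)(C)CC3=O)cc(OC)c1OC`: "not active" (no number reported)
Compound 3 `COc1cc(N2C(N)=C(C#N)C(c3c(O)ccc4ccccc34)C3=C2CC(C)(C)CC3=O)cc(OC)c1OC`: 143000 nM

Among the compounds with values here, in a functional assay on Ehrlich cells (Mus musculus) for cytotoxicity (on this read-out lower numbers stand for stronger inhibition and higher numbers for weaker inhibition), compound 3 gives 143000 nM, the only number in this small set; compound 1 and compound 2 returned no number at all. Compound 3 therefore stands alone as the single measured point, and there is nothing to compare it with directly. Compound 4 `COc1cc(N2C(N)=C(C#N)C(c3ccc(Cl)cc3Cl)C3=C2CC(C)(C)CC3=O)cc(OC)c1OC` differs from it in one place: 2,4-dichlorophenyl in place of 2-hydroxynaphthalen-1-yl on a saturated ring carbon. Within the data shown here, with no measured pair of neighbours to learn from, the expectation is that compound 4 stays weak, with the step of a 1.4-fold higher number from compound 3 to compound 4 (0.15 log units; within the scatter) expected to be modest and possibly not beyond the usual scatter. Compound 4 is therefore estimated at 200000 nM, with a plausible range from 60000 nM to 600000 nM, and a real chance that no number is obtained.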

Compound 4, half-maximal inhibitory concentration: 94700 nM
The estimate for compound 4 lay 2.1-fold (0.32 log units) above the measured number; low and high end bracket the measured number.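

In this assay the change to 2,4-dichlorophenyl from 2-hydroxynaphthalen-1-yl on this saturated ring carbon gives a 1.5-fold lower number from compound 3 to compound 4 (0.18 log units; within the scatter) and so separates the two compounds by no real margin. A number can therefore be obtained at this position without the hydroxyl group or the second aromatic ring, though activity remains weak. No measurement here explains why the two groups give such similar values. On these data alone, whether an amine or a carboxylic acid on the phenyl ring would give clearly stronger inhibition remains open. So does whether either chlorine matters on its own.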